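Chloro for trifluoromethyl on the arylsulfonyl series

This account rests on a few compounds, and the source may have more. Where it says the series, first, only, none or still open, it means among the compounds named here.

Going by the values given here, in a functional assay on HCT-116 cells (Homo sapiens) for inhibition, read by resazurin assay, with a stated time of 5 days (on this read-out higher numbers stand for weaker inhibition of growth and lower numbers for stronger inhibition of growth), compound 2 (`O=C(CCCC1CCN(S(=O)(=O)Nc2ccccc2)CC1)NO`) gives 2000 nM, the only number so far in this small set. Compound 1 (`Cc1ccccc1S(=O)(=O)N1CCC(CCCC(=O)NO)CC1`) has the entry "not determined" (no result reported). Among the compounds with values here, compound 3 (`O=C(CCCC1CCN(S(=O)(=O)c2ccccc2C(F)(F)F)CC1)NO`) also has the entry "not determined" (no result reported), so it has no place on the scale, and compound 1 is the one other compound without a number.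

Compound 4 (`O=C(CCCC1CCN(S(=O)(=O)c2ccccc2Cl)CC1)NO`) has yet to be measured. The structural change is chloro in place of trifluoromethyl on an aromatic carbon, ortho to a large group. The shared core and the hydroxamic acid chain stay as they are.

Within the data shown here, no measured step in the set shows what such a swap does, and compound 3 offers no number to start from. The expectation in this assay is therefore a step no larger than the usual scatter, with no direction favoured. Among the measured compounds shown here, the only anchor is compound 2 at 2000 nM. For compound 4 the estimated value is 1500 nM, with an expected range of 400 nM to 5000 nM.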

Compound 4, concentration for 50% growth inhibition: 2800 nM
Compound 4: middle estimate off by 1.9-fold (0.27 log units), on the low side; low and high end bracket the measured number.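

Compound 4 gives the series a second number in this assay, and 2-chlorophenyl in place of anilino on the sulfonyl sulfur reads as a 1.4-fold higher number from compound 2 to compound 4 (0.15 log units; within the scatter). An aryl group bearing chloro and joined directly to the sulfur therefore gives a value that cannot be told apart from that of the anilino compound. Steps involving compound 1 or compound 3, including chloro in place of trifluoromethyl, cannot be read, as neither compound has a number, and no measurement bears on the reason for this result.

Open, from the compounds shown here alone, is what a hydrogen, a methoxy group or a nitrile would give on that same aromatic carbon in this assay. Also open, going by these compounds, is how a carboxylic acid in place of the hydroxamic acid, or a longer chain, would read against compound 4.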